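Urea analogue of compound 3 in the melanoma cell assay

The source may hold more compounds than are shown below. What is called first, only, known or untested is meant among the compounds shown, and "the series" means these compounds.

Working notes on the series. In a functional assay on LOX IMVI cells (Homo sapiens) for inhibition, read by sulforhodamine B assay, with a stated time of 48 h (on this read-out lower numbers stand for higher toxicity in this test and higher numbers for lower toxicity in this test), compound 3 `COc1cc(-c2nn(-c3cccc(NC(=O)c4ccc(Cl)c(C(F)(F)F)c4)c3)cc2-c2ccncc2)ccc1Cl` gives > 32500 nM, which is a limit of the assay rather than a number. Compound 1 `COc1cc(-c2nn(-c3cccc(NC(=O)c4cccc(C(F)(F)F)c4)c3)cc2-c2ccncc2)ccc1Cl` gives > 50000 nM in this assay, again a limit. Compound 2 `COc1cc(-c2nn(-c3cccc(NC(=O)Nc4ccc(Cl)c(Cl)c4)c3)cc2-c2ccncc2)ccc1Cl` gives > 50000 nM in this assay, also a limit. Going by the values given here, all three measured values therefore sit at limits, two of them at the limit of > 50000 nM in this assay, at which 2 of the 3 values shown sit, and one at the limit of > 32500 nM in this assay, at which 1 of the 3 values shown sits, and no compound can be placed above another.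

Compound 4 `COc1cc(-c2nn(-c3cccc(NC(=O)Nc4ccc(Cl)c(C(F)(F)F)c4)c3)cc2-c2ccncc2)ccc1Cl` differs from compound 3 by (4-chloro-3-(trifluoromethyl)phenyl)amino in place of 4-chloro-3-(trifluoromethyl)phenyl on a carbonyl carbon. The measured steps that bear on this change are a step that the two limits leave unreadable from compound 1 to compound 2, a step that the two limits leave unreadable from compound 1 to compound 3 and a step that the two limits leave unreadable from compound 2 to compound 3; none of them is readable in size, since both ends of each sit at a limit. A step of no readable size beyond the scatter is therefore expected for a step that the limit leaves unreadable from compound 3 to compound 4, with the result most likely reported as a limit again. Compound 4 is estimated at 60000 nM, within 30000 nM to 150000 nM.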

Compound 4, concentration lethal to 50% of the cells: 17900 nM
The estimate for compound 4 lay 3.4-fold (0.53 log units) above the measured number; the whole stated range lies above it.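

In this assay, compound 4 alone among the compounds shown carries a number rather than a limit, so the urea bearing both the chloro and the trifluoromethyl on its phenyl ring is the one readable point in the series. Trifluoromethyl in place of chloro on an aromatic carbon gives an at least 2.7-fold lower number from compound 2 to compound 4 (0.44 log units; beyond the scatter), and (4-chloro-3-(trifluoromethyl)phenyl)amino in place of 3-(trifluoromethyl)phenyl on a carbonyl carbon gives an at least 2.7-fold lower number from compound 1 to compound 4 (0.44 log units; beyond the scatter). The exchange of 4-chloro-3-(trifluoromethyl)phenyl for its amino counterpart on the carbonyl carbon gives an at least 1.8-fold lower number from compound 3 to compound 4 (0.25 log units; that floor lies within the scatter), so this change alone is not shown to exceed the scatter.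

The value of compound 3 is a limit, which leaves the full size of that step open: the limit of > 32500 nM in this assay, at which 1 of the 4 values shown sits.

From the compounds shown here alone, the steps among compound 1, compound 2 and compound 3 cannot be read, and what a nitrile or a carboxylic acid in place of the trifluoromethyl would give remains open.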